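Propyl to hydroxymethyl on the aryl ether of compound 1

A few compounds are considered here, and "the series" means these few. Any claim that something is new, unique, unknown or untested is made for them only; others in the source may bear on it.

Compound 1 `CCCc1ccc(OCC(=O)N(CC)Cc2cccs2)cc1` is measured in an assay on HEK293 cells for agonist activity at transient receptor potential cation channel subfamily M member 8 (Homo sapiens), read by fluorescence and calcium flux, with a stated time of 15 min (on this read-out lower numbers stand for an effect already at smaller amounts and higher numbers for an effect only at larger amounts of compound), and gives 1810 nM. Of the three numbers recorded, this is the second highest. Compound 3 `CCN(Cc1nccs1)C(=O)COc1ccc(C)cc1` gives 3060 nM, within the scatter of compound 1, so no order between the two is claimed. Compound 2 `O=C(COc1ccc2c(c1)CCC2)N(Cc1cccs1)c1ccn[nH]1` gives 0.001 nM, far lower than compound 1 and beyond the scatter; compound 2 differs from compound 1 in several places at once, so nothing is drawn from that gap about any single change.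

Compound 4 `CCN(Cc1cccs1)C(=O)COc1ccc(CO)cc1` is not yet measured. It differs from compound 1 by hydroxy in place of ethyl on a saturated chain carbon bound to an aromatic carbon; cut one bond further out, the same difference reads propyl to hydroxymethyl. Within the data shown here, no pair in the set isolates this change. Among the measured compounds shown here, the only related comparison is compound 3 against compound 1, where a smaller group on the same aromatic ring, alongside a change elsewhere, leaves the number within the scatter. The step from compound 1 to compound 4 is therefore expected to be small, a 1.7-fold higher number from compound 1 to compound 4 (0.22 log units; within the scatter), most likely toward a somewhat higher number, though a result within the scatter would not surprise. Compound 4 is estimated at 3000 nM, with a range from 1000 nM to 15000 nM.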

Compound 4, half-maximal effective concentration: 21900 nM
Beside the measured number, compound 4's estimate is 7.3-fold (0.86 log units) below it, and the stated range ends below it.
By their numbers in this assay, from the lowest: compound 2; then compounds 1 and 3 (each within the scatter of the next); then compound 4.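

In this assay, among these compounds, the change from propyl to hydroxymethyl gives a 12-fold higher number from compound 1 to compound 4 (1.08 log units; beyond the scatter) and is the first step that isolates a single place. The saturated chain carbon bound to an aromatic carbon is thus not indifferent to its substituent: replacing ethyl with hydroxy moves the number beyond the scatter, something the comparison of compound 3 with compound 1, which differ in more than one place, could not show. No measurement available here accounts for this step.

As far as these compounds go, it remains open whether the step follows the hydroxy group or the shorter chain; a butyl chain, a methoxymethyl group or an aminomethyl group in the same place would help separate the two. Also open, from the compounds shown here alone, is whether hydroxymethyl has a similar effect on the core of compound 2.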